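The source may report more compounds than this note shows. Statements on the series, on what has been measured and on what is new or still open speak of the compounds shown alone.

Compound 1 `COc1cc(/C=C/C(=O)/C=C/c2cccc3ccccc23)ccc1OCc1cn(CCCOc2cc(=O)oc3ccccc23)nn1`: 71%
Compound 2 `COc1cc(/C=C/C(=O)/C=C/c2cccc3ccccc23)ccc1OCc1cn(CCCCCOc2cc(=O)oc3ccccc23)nn1`: 44%

In a functional assay on THP-1 cells (Homo sapiens) for inhibition, read by sulforhodamine B assay, with a stated time of 48 h, tested at 50 uM (on this read-out higher numbers stand for more inhibition of growth at the one concentration tested and lower numbers for less inhibition of growth), compound 1 gives 71%, the higher of the two numbers. Compound 2 gives 44%, and the gap between them lies beyond the usual scatter. Compound 3 `COc1cc(/C=C/C(=O)/C=C/c2cc(OC)c(OC)c(OC)c2)ccc1OCc1cn(CCCOc2cc(=O)oc3ccccc23)nn1` has not yet been measured. It keeps the core of compound 1 and differs from it in one place: 3,4,5-trimethoxyphenyl in place of naphthalen-1-yl on a double-bonded chain carbon bound to a double-bonded chain carbon. Here 3,4,5-trimethoxyphenyl stands in place of naphthalen-1-yl, on a double-bonded chain carbon bound to a double-bonded chain carbon. Within the data shown here, no measured pair shows this exchange, so the data offer no direct guide to its size. Among the measured compounds shown here, since compound 1 holds the top value so far, a modest fall is expected rather than a rise, and it may stay within the scatter. The expected change in this assay is a number 9 percentage points lower from compound 1 to compound 3 (within the scatter). For compound 3 the estimated value is 62%, with an expected range from 40% to 82%.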

Compound 3, percent growth inhibition at one concentration: 79%
Compound 3: the middle estimate sits 17 percentage points below what was measured; low and high end bracket the measured number.
By their numbers in this assay, from the lowest: compound 2; then compounds 1 and 3 (each within the scatter of the next).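

In this assay, putting 3,4,5-trimethoxyphenyl in place of naphthalen-1-yl on a double-bonded chain carbon bound to a double-bonded chain carbon gives a number 8 percentage points higher from compound 1 to compound 3 (within the scatter) for this exchange. The earlier compounds shown here offered no exchange at this position, and this step shows that it accepts one six-membered aromatic ring of carbon only with 3 hydrogen-bond acceptors in place of 2 such rings with 0 acceptors, with no change that can be told from the scatter. Nothing available accounts for this outcome. Going by these compounds, whether a plain phenyl, or a ring bearing an amine or a carboxylic acid, would fare the same at this position remains open. So does whether 3,4,5-trimethoxyphenyl would give a similar result on the longer chain of compound 2.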